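From Fluoro to Methyl on One Series

The source may hold more compounds than are shown below. What is called first, only, known or untested is meant among the compounds shown, and "the series" means these compounds.

The account follows three compounds built on one shared core and tested in an assay on isolated protein for inhibition of alpha-galactosidase (Coffea arabica), tested at 1000 uM; a higher number here means more inhibition at the concentration tested (going by the name of the read-out), a lower number less inhibition. Compound 1 `OC[C@]1(c2ccc(F)cc2)NC[C@H](O)[C@H]1O` gives 0%, the lowest of the three numbers. Compound 2 `OC[C@@]1(c2ccc(O)cc2)NC[C@@H](O)[C@@H]1O` gives 1.2% in this assay, and compound 3 `COc1cccc([C@]2(CO)NC[C@@H](O)[C@@H]2O)c1` gives 1.6%; both numbers lie within the scatter of the number for compound 1, so no order can be drawn among the three. Compound 4 `Cc1ccc([C@@]2(CO)NC[C@H](O)[C@H]2O)cc1` has not yet been measured. It differs from compound 1 in one place: methyl in place of fluoro on an aromatic carbon. Among the compounds with values here, no pair of measured compounds differs in a single place, so there is no measured step by which to gauge this change. What the data show is that compound 1, compound 2 and compound 3 all sit at the floor of the read-out whatever group the aromatic ring carries. The step of a number 2 percentage points higher from compound 1 to compound 4 (within the scatter) is therefore expected to stay within the scatter, in no particular direction. Compound 4 is estimated at 2%, with a range from 0% to 12%.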

Compound 4, a percentage reported as inhibition, at one concentration (the size of the read-out at that concentration, not a potency): 0%
For compound 4 the middle estimate is 2 percentage points above the measured one; measured number inside the range.
By their numbers in this assay, from the lowest: compounds 1, 4, 2 and 3 (each within the scatter of the next).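

The step gives the series its first comparison in one place: in this assay, methyl in place of fluoro on an aromatic carbon, para to a group of 9 heavy atoms, gives no change at the digits printed from compound 1 to compound 4 (within the scatter), with the read-out at its floor at both ends. Within the data shown here, at this position, then, the exchange of one single-atom group for another leaves the number unmoved, which the earlier compounds, none of them a single change apart, could not show directly. No measurement offered here bears on why this is so.

Going by these compounds, whether an amine, a carboxylic acid or a longer chain in this place would lift the number off the floor remains open. Also open, on these data alone, is whether methyl and fluoro would still read alike on an enzyme where the shared core gives a measurable inhibition.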